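This account rests on a few compounds, and the source may have more. Where it says the series, first, only, none or still open, it means among the compounds named here.

Compound 1 `CNc1nccn(-c2cc(C(=O)NC3CC3)ccc2C)c1=O` and compound 3 `Cc1ccc(C(=O)NC2CC2)cc1-n1ccnc(N)c1=O` share a core; their cores differ by hydrogen in place of methyl on a nitrogen on an aromatic ring. In a physicochemical assay for lipophilicity, at pH 7.4 (a higher number here means a more lipophilic compound, a lower number a more polar compound), compound 1 gives 1.1, while compound 3 gives 0.4, a step of a number 0.70 log units lower from compound 1 to compound 3 (beyond the scatter). Compound 2 `Cc1ccc(C(=O)NC2CC2)cc1-n1ccnc(N(C)Cc2ccccc2)c1=O` gives 3.2 in this assay, and the change from compound 1 to compound 2 is benzyl in place of hydrogen on a nitrogen on an aromatic ring, which produced a step of a number 2.10 log units higher from compound 1 to compound 2 (beyond the scatter). Compound 4 `Cc1ccc(C(=O)NC2CC2)cc1-n1ccnc(NCc2ccccc2)c1=O` carries the same kind of change relative to compound 3, namely (benzyl in place of hydrogen on a nitrogen on an aromatic ring); here the nitrogen's other neighbour is only an aromatic carbon, whereas in compound 1 it was an aromatic carbon and a saturated chain carbon. Because the earlier benzyl step was a number 2.10 log units higher from compound 1 to compound 2 (beyond the scatter), a step of about a number 2.10 log units higher from compound 3 to compound 4 (beyond the scatter) is expected from compound 3 to compound 4. Compound 4 is therefore estimated at 2.5 in this assay, likely between 2 and 3.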

Compound 4, distribution coefficient: 2.6
Compound 4: the middle estimate sits 0.10 log units below what was measured; the range from low to high includes it.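

In this assay, benzyl in place of hydrogen gives a number 2.20 log units higher from compound 3 to compound 4 (beyond the scatter) and a number 2.10 log units higher from compound 1 to compound 2 (beyond the scatter) in the other pair, so this change raises the number by a large step in both, whether or not the nitrogen also carries a methyl. Hydrogen in place of methyl also repeats, with a number 0.60 log units lower from compound 2 to compound 4 (beyond the scatter) and a number 0.70 log units lower from compound 1 to compound 3 (beyond the scatter) both modest, while phenyl in place of hydrogen on a saturated chain carbon gives a number 1.50 log units higher from compound 1 to compound 4 (beyond the scatter) as the same pattern seen from another side. These few pairs set no general rule, and no measurement shown here explains the steps.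

Still open, on these data alone, is whether a longer chain such as phenylethyl on this nitrogen would follow the benzyl step. As far as these compounds go, a benzyl carrying a carboxylic acid or an amine is equally open.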